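The source may report more compounds than this note shows. Statements on the series, on what has been measured and on what is new or still open speak of the compounds shown alone.

For the measured compounds named here, compound 2, `CCC1(Cc2ccccc2)OS(=O)(=O)C=C1OCc1ccc(Br)cc1`, is the only member of this pair of measured compounds with a plain number in an ADME assay on HEL cells (Homo sapiens) for cytotoxicity, with a stated time of 3 days; a higher number here means that more compound is tolerated, a lower number that less compound is tolerated: compound 2 gives 80000 nM. Compound 1, `CCC1(Cc2ccccc2)OS(=O)(=O)C=C1OCc1cccc(Cl)c1`, gives only a limit of the assay in this assay, namely >= 20000 nM. Going by the values given here, the single measured step, a step that the limit leaves unreadable from compound 1 to compound 2, therefore cannot be read, as the limit of >= 20000 nM in this assay, at which 1 of the 2 values shown sits, makes clear.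

Compound 3, `CCC1(Cc2ccccc2)OS(=O)(=O)C=C1OCC=C(C)C`, is not yet measured. Its change from compound 2 is 2-methylprop-1-en-1-yl in place of 4-bromophenyl on a saturated chain carbon bound to an oxygen on an unsaturated carbon. Among the compounds with values here, no measured step bears on an exchange of this kind, so no direction can be drawn from the data; the expectation is that compound 3 stays close to compound 2, with the step of no change at the digits printed from compound 2 to compound 3 (within the scatter) expected to lie within the scatter. Compound 3 is estimated to give 80000 nM in this assay, expected to fall between 30000 nM and 200000 nM.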

Compound 3, minimum cytotoxic concentration: 400000 nM
Estimate against measurement, compound 3: 5.0-fold (0.70 log units) below; the whole stated range lies below it.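

For the compounds shown here, at this position, on a saturated chain carbon bound to an oxygen on an unsaturated carbon, the exchange of 4-bromophenyl for 2-methylprop-1-en-1-yl gives the first readable step in this assay, with a 5.0-fold higher number from compound 2 to compound 3 (0.70 log units; beyond the scatter). The result shows that this position affects the read-out and that, in this pair, the group without a ring is the better tolerated. Compound 1 gives a limit of the assay, so its steps to compound 2 and compound 3 cannot be read: the limit of >= 20000 nM in this assay, at which 1 of the 3 values shown sits.

This single pair does not separate the loss of the aromatic ring from the loss of the bromine or the arrival of the double bond. A plain benzyl group or a saturated 3-methylbutyl chain at this position would bear on that question.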